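The compounds below may be only part of what the source reports. "The series", "measured", "known", "first", "only" and "open" are said of these compounds alone.

In a functional assay on SMMC-7721 cells (Homo sapiens) for antiproliferative activity, read by MTT assay, with a stated time of 48 h (a higher number here means a weaker inhibitor, a lower number a stronger inhibitor), compound 1 `CC(C)=CCC[C@]1(C)/C=C/[C@@H](OC(=O)C=C(C)C)[C@](C)(O)/C=C/C(=O)/C(CN(C)C)=C\C1` gives 820 nM, compound 2 `CC(C)=CCC[C@]1(C)/C=C/[C@@H](OC(=O)C=C(C)C)[C@](C)(O)/C=C/C(=O)/C(CN2CCCC2)=C\C1` gives 140 nM and compound 3 `CC(C)=CCC[C@]1(C)/C=C/[C@@H](OC(=O)C=C(C)C)[C@](C)(O)/C=C/C(=O)/C(C[Si](C)(C)C(C)(C)C)=C\C1` gives 4000 nM, the highest of the three numbers and so the weakest inhibitor. Compound 4 `CC(C)=CCC[C@]1(C)/C=C/[C@@H](OC(=O)C=C(C)C)[C@](C)(O)/C=C/C(=O)/C(C(=O)N(C)C)=C\C1` differs from compound 3 on a double-bonded ring carbon: a group of 5 heavy atoms (3 carbon, 1 nitrogen, 1 oxygen; no ring) in place of a group of 8 heavy atoms (7 carbon, 1 silicon; no ring), on a double-bonded ring carbon. The relevant measured steps are modest to large: a 4.9-fold higher number from compound 1 to compound 3 (0.69 log units; beyond the scatter), a 29-fold higher number from compound 2 to compound 3 (1.46 log units; beyond the scatter) and a 5.9-fold lower number from compound 1 to compound 2 (0.77 log units; beyond the scatter). Like compound 1, with 820 nM, compound 4 has a nitrogen bearing two methyl groups, but no measured compound has a carbonyl in this group, so a full return to that value is uncertain. A modest fall in this assay is therefore expected, a 2.7-fold lower number from compound 3 to compound 4 (0.43 log units; beyond the scatter). For compound 4 the estimated value is 1500 nM, with an expected range of 450 nM to 5000 nM.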

Compound 4, half-maximal inhibitory concentration: 3670 nM
Compound 4: the middle estimate sits 2.4-fold (0.39 log units) below what was measured; the measured number falls inside the stated range.
By their numbers in this assay, from the lowest: compound 2; then compound 1; then compounds 4 and 3 (each within the scatter of the next).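

Exchanging the (dimethylamino)methyl group for dimethylcarbamoyl keeps the nitrogen with its two methyl groups and adds a carbonyl, yet a 4.5-fold higher number from compound 1 to compound 4 (0.65 log units; beyond the scatter) in this assay, and a 26-fold higher number from compound 2 to compound 4 (1.42 log units; beyond the scatter). The silicon-bearing group and dimethylcarbamoyl give matching results, with a 1.1-fold lower number from compound 3 to compound 4 (0.04 log units; within the scatter), so those two methyl groups on nitrogen do not by themselves preserve the activity of compound 1. No supporting data explain this result.

From the compounds shown here alone, whether a pyrrolidin-1-ylcarbonyl group would match compound 2 remains open. So does the outcome with a carboxylic acid at this ring carbon.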